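The source may hold more compounds than are shown below. What is called first, only, known or untested is meant among the compounds shown, and "the series" means these compounds.

Measured so far:
compound 1, `O=C(c1ccc(O)cc1O)[C@H]1[C@H](C(=O)c2ccc(O)cc2O)[C@H](c2ccccc2)[C@@H]1c1ccccc1`: 30.7%
compound 2, `O=C(c1ccc(O)cc1O)[C@@H]1[C@@H](C(=O)c2ccc(O)cc2O)[C@H](c2ccccc2)[C@H]1c1ccccc1`: 41.2%

Both were tested in a functional assay on PC-3 cells (Homo sapiens) for cytotoxicity, read by MTT assay, with a stated time of 48 h, tested at 5 uM; a lower number here means a weaker effect, a higher number a stronger effect of the compound at the concentration tested. Of the two numbers, compound 2 stands highest, with compound 1 nearest; the change a number 10.5 percentage points higher from compound 1 to compound 2 (beyond the scatter) separates them. These two share every atom and bond and differ only in configuration, as captured by the fact that compounds 1 and 2 differ only in the configuration as drawn, so this step shows how much a change of configuration alone can move the read-out here.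

Compound 3, `O=C(c1ccc(O)cc1O)[C@H]1[C@H](C(=O)c2ccc(O)cc2O)[C@@H](c2ccccc2)[C@@H]1c1ccccc1`, has not yet been measured. Compared with compound 2 it differs as follows: the two compounds have the same atoms and bonds and differ only in configuration as drawn: 4 of 4 stereo elements differ (all stereocentres are inverted: mirror images); a stereocentre at a saturated ring carbon is drawn S in compound 2 and R in compound 3; a stereocentre at a saturated ring carbon is drawn S in compound 2 and R in compound 3; a stereocentre at a saturated ring carbon is drawn R in compound 2 and S in compound 3; a stereocentre at a saturated ring carbon is drawn R in compound 2 and S in compound 3. Compound 3 is thus the mirror image of compound 2, whereas compound 1 is a mirror image of neither. Among the compounds with values here, the only measured step that bears on a change of configuration is a number 10.5 percentage points higher from compound 1 to compound 2 (beyond the scatter), a modest shift. Within the data shown here, no measured pair here shows a mirror-image step directly, so the direction is open. Compound 3 is expected to land near compound 2, with the step of a number 5.2 percentage points lower from compound 2 to compound 3 (within the scatter) likely within the scatter but with room for a shift of the size of a number 10.5 percentage points higher from compound 1 to compound 2 (beyond the scatter) in either direction. Compound 3 is estimated at 36%, between 20% and 52%.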

Compound 3, a percentage reported as activity, at one concentration (the size of the read-out at that concentration, not a potency): 49.7%
For compound 3 the middle estimate is 13.7 percentage points below the measured one; the range from low to high includes it.
By their numbers in this assay, from the lowest: compound 1; then compounds 2 and 3 (each within the scatter of the next).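

In this assay the mirror-image step is a number 8.5 percentage points higher from compound 2 to compound 3 (within the scatter), so this pair of mirror images shows no clear preference for one hand, and the two compounds can be told apart only by their drawn configuration: the fact that compounds 2 and 3 differ only in the configuration as drawn The larger step comes from inverting just one stereocentre at a saturated ring carbon, a number 19 percentage points higher from compound 1 to compound 3 (beyond the scatter), so the number of inverted centres does not set the size of the step: one centre moves the read-out beyond the scatter here, while inverting all of them does not. Only configuration can lie behind this step, because nothing else separates the two compounds: the fact that compounds 1 and 3 differ only in the configuration as drawn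

These read-outs come from a single concentration on one cell type, so they show the size of the effect at that concentration only and leave open how the three compounds would compare at other concentrations. On these data alone, it also remains open whether this one stereocentre would matter as much with an amine or a carboxylic acid in place of the hydroxyl groups on the shared core.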